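The source may report more compounds than this note shows. Statements on the series, on what has been measured and on what is new or still open speak of the compounds shown alone.

Compound 2 `COc1ccc(CN(C(C)=O)c2cc(OC)c(OC)c(OC)c2)cc1O`: 160 nM
Compound 3 `C/C=C/C(=O)N(Cc1ccc(OC)c(Cl)c1)c1cc(OC)c(OC)c(OC)c1`: 10100 nM
Compound 1 `C/C=C/C(=O)N(Cc1cccc(O)c1)c1cc(OC)c(OC)c(OC)c1`: 14700 nM

In a functional assay on KYSE-450 cells (Homo sapiens) for inhibition, read by MTT assay, with a stated time of 48 h (a higher number here means a weaker inhibitor, a lower number a stronger inhibitor), compound 2 stands lowest of the three numbers, with compound 3 and compound 1 both lying beyond the scatter above it. Compound 4 `COc1ccc(CN(C(=O)CO)c2cc(OC)c(OC)c(OC)c2)cc1O` differs from compound 2 by hydroxy in place of hydrogen on a saturated chain carbon bound to a carbonyl carbon. Among the measured compounds shown here, the only single-site step measured, a 1.5-fold lower number from compound 1 to compound 3 (0.16 log units; within the scatter), concerns the group on the saturated chain carbon bound to the amide-type nitrogen, not the acyl part, and lies within the scatter; compound 1 and compound 3 each differ from compound 2 at two places at once, so their gaps give no clean reading of the acyl side. Nothing measured bears directly on the change, so no step beyond the scatter is expected in this assay. Compound 4 is therefore estimated at 250 nM, with a range of 80 nM to 800 nM, meaning an expected step of a 1.6-fold higher number from compound 2 to compound 4 (0.19 log units; within the scatter).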

Compound 4, half-maximal inhibitory concentration: 370 nM
Beside the measured number, compound 4's estimate is 1.5-fold (0.17 log units) below it; low and high end bracket the measured number.
By their numbers in this assay, from the lowest: compound 2; then compound 4; then compounds 3 and 1 (each within the scatter of the next).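

In this assay the acyl side of the shared core now has its first clean reading, a 2.3-fold higher number from compound 2 to compound 4 (0.36 log units; beyond the scatter), a modest step that lies beyond the scatter. Hydroxy in place of hydrogen on the saturated chain carbon bound to the carbonyl carbon therefore weakens inhibition a little, rather than leaving it unchanged. Nothing measured here gives a reason for this step. Going by these compounds, whether an amine, a fluorine or a longer chain at this carbon would give a similar step remains open, as does whether the step would hold with a different group on the amide-type nitrogen.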